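The source may report more compounds than this note shows. Statements on the series, on what has been measured and on what is new or still open speak of the compounds shown alone.

In an ADME assay on PA-1 cells (Homo sapiens) for cytotoxicity, read by MTT assay, with a stated time of 72 h (a lower number here means a stronger inhibitor, a higher number a weaker inhibitor), compound 1 `COc1ccc(C2=C(c3cc(OC)c(OC)c(OC)c3)C(=O)CC2O[SiH2]C(C)(C)C)cc1` gives > 100 ug/mL, which is a limit and not a number. Compound 2 `COc1ccc(C2=C(c3cc(OC)c(OC)c(OC)c3)C(=O)CC2O[SiH2]C(C)(C)C)cc1OC` gives > 100 ug/mL, also a limit. Going by the values given here, compound 3 `COCOc1cc(C2=C(c3cc(OC)c(OC)c(OC)c3)C(=O)CC2O[SiH2]C(C)(C)C)ccc1OC` gives 13.5 ug/mL, the only true number so far. Compound 4 `COc1ccc(C2=C(c3cc(OC)c(OC)c(OC)c3)C(=O)CC2O[SiH2]C(C)(C)C)cc1O` differs from compound 3 by hydrogen in place of methoxymethyl on an oxygen on an aromatic ring, which turns methoxymethoxy to hydroxy. Two measured steps involve this same group: an at least 7.4-fold lower number from compound 1 to compound 3 (0.86 log units; beyond the scatter) and an at least 7.4-fold lower number from compound 2 to compound 3 (0.86 log units; beyond the scatter). They show that changes at this place can move the number, but both start from limits and neither involves hydroxy. The expected change is modest, a 2.3-fold lower number from compound 3 to compound 4 (0.35 log units; beyond the scatter), towards a lower number. For compound 4, the estimated value is 6 ug/mL, with an expected range from 1 ug/mL to 35 ug/mL.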

Compound 4, half-maximal inhibitory concentration: 14 ug/mL
The estimate for compound 4 lay 2.3-fold (0.37 log units) below the measured number; the measured number falls inside the stated range.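

In this assay, hydrogen in place of methoxymethyl on this oxygen gives a 1.0-fold higher number from compound 3 to compound 4 (0.02 log units; within the scatter), so the two groups cannot be told apart here and the methoxymethyl is not needed for the number seen with compound 3. Hydrogen in place of the methyl on this oxygen gives an at least 7.1-fold lower number from compound 2 to compound 4 (0.85 log units; beyond the scatter), and hydroxy in place of hydrogen on the aromatic carbon gives an at least 7.1-fold lower number from compound 1 to compound 4 (0.85 log units; beyond the scatter). Both of these steps start from a limit, so their true size stays open: the limit of > 100 ug/mL in this assay, at which 2 of the 4 values shown sit.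

As far as these compounds go, whether a longer chain on this oxygen, or an amine in place of the hydroxy, would give a number like that of compound 4 remains open.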